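Replacing the piperazin-1-yl group with an untested tail

The source may report more compounds than this note shows. Statements on the series, on what has been measured and on what is new or still open speak of the compounds shown alone.

The measured compounds:
Compound 1, `Cc1cc(NC(C)C)nc(SCc2nc3ccccc3[nH]2)n1`. In a functional assay on ECa-109 cells (Homo sapiens) for cytotoxicity, read by MTT assay, with a stated time of 72 h (a lower number here means a stronger inhibitor, a higher number a weaker inhibitor), compound 1 gives > 100000 nM, which is a limit of the assay and not a number.
Compound 2, `Cc1cc(N2CCCCC2)nc(SCc2nc3ccccc3[nH]2)n1`. In this assay compound 2 gives > 100000 nM, again a limit.
Compound 3, `Cc1cc(N2CCNCC2)nc(SCc2nc3ccccc3[nH]2)n1`. In this assay compound 3 gives > 100000 nM, also a limit.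

Compound 3 therefore stands where every value shown stands: at the limit of > 100000 nM in this assay, at which 3 of the 3 values shown sit. Among the measured compounds shown here, no measured compound has a number of its own, so the three steps among them, a step that the two limits leave unreadable from compound 1 to compound 2, a step that the two limits leave unreadable from compound 1 to compound 3 and a step that the two limits leave unreadable from compound 2 to compound 3, cannot be read, because both ends of each step sit at the limit of > 100000 nM in this assay, at which 3 of the 3 values shown sit.

Compound 4, `Cc1cc(NNC(N)=S)nc(SCc2nc3ccccc3[nH]2)n1`, is not yet measured. It differs from compound 3 by a group of 5 heavy atoms (1 carbon, 3 nitrogen, 1 sulfur; no ring) in place of a group of 6 heavy atoms (4 carbon, 2 nitrogen; one six-membered non-aromatic ring with 2 hetero atoms), on an aromatic carbon. No measured step bears on this change in a readable way; the only thing the shown data tell is that three different groups at this position, isopropylamino, piperidin-1-yl and piperazin-1-yl, all left the compound at the limit. On that basis the expectation is that compound 4 also reaches no number, and its expected value is 100000 nM, within a range of 20000 nM to 300000 nM. That estimate amounts to a step of a number no higher from compound 3 to compound 4 (the limit leaves the size open), which is an expectation and not a reading.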

Compound 4, half-maximal inhibitory concentration: > 100000 nM
Compound 4 gave a limit, no number; the forecaster's own chance of this, stated with the estimate: 70%; the middle value lies on the limit itself.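

Compound 4 gives a limit of the assay and not a number, so its steps from compound 1, compound 2 and compound 3 cannot be read, as all four compounds share one limit: the limit of > 100000 nM in this assay, at which 4 of the 4 values shown sit.

The compounds shown leave open how far apart these four really lie, and whether any other group at this place on the shared core would give a number of its own in this assay.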